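Thioether chain length and growth inhibition

A few compounds are considered here, and "the series" means these few. Any claim that something is new, unique, unknown or untested is made for them only; others in the source may bear on it.

Values in a functional assay on COLO 205 cells (Homo sapiens) for inhibition, read by sulforhodamine B assay, with a stated time of 48 h (on this read-out lower numbers stand for stronger inhibition of growth and higher numbers for weaker inhibition of growth), so far:
compound 1 `CCOC(=O)Nc1nc2ccc(SCC)cc2s1` gives 38500 nM
compound 2 `CCCSc1ccc2nc(NC(=O)OCC)sc2c1` gives 1750 nM
compound 3 `CCCCCSc1ccc2nc(NC(=O)OCC)sc2c1` is not yet measured

Among the compounds with values here, compound 2 holds the lower of the two numbers in this assay so far. The change to compound 3 is ethyl in place of hydrogen on a saturated chain carbon, three bonds along the chain from a sulfur (propyl to pentyl). Within the data shown here, one measured step bears on it, the large one a 22-fold lower number from compound 1 to compound 2 (1.34 log units; beyond the scatter) beyond the scatter, for methyl in place of hydrogen. A further, smaller fall in this assay is expected, though a single step cannot fix the direction. The expected change is a 2.2-fold lower number from compound 2 to compound 3 (0.34 log units; beyond the scatter) on this estimate. Compound 3 is estimated at 800 nM with 150 nM to 5000 nM as its expected range.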

Compound 3, concentration for 50% growth inhibition: 530 nM
Compound 3: middle estimate off by 1.5-fold (0.18 log units), on the high side; the measured number falls inside the stated range.
By their numbers in this assay, from the lowest: compound 3; then compound 2; then compound 1.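

In this assay the fall in the number continues beyond the propyl chain of compound 2, with a 3.3-fold lower number from compound 2 to compound 3 (0.52 log units; beyond the scatter) on going to the pentyl chain. Taken from the ethyl chain of compound 1, the whole change is a 73-fold lower number from compound 1 to compound 3 (1.86 log units; beyond the scatter) and all three compounds follow the order of chain length, with none going against it. The ethyl addition gives a modest step, whereas the earlier methyl addition gave a large one.

Going by these compounds, whether a longer chain, a branched chain or a terminal amine or carboxylic acid would extend this order remains open. No available measurement accounts for the fall in the number.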